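The source may report more compounds than this note shows. Statements on the series, on what has been measured and on what is new or still open speak of the compounds shown alone.

Measured compounds in a functional assay on the whole organism (strain Kunming) with Mus musculus as the target, with a stated time of 0.5 h, at a dose of 300 mg/kg by the intraperitoneal route; a higher number here means a weaker effect of the compound at the dose given, a lower number a stronger effect:
compound 1, `COc1ccccc1/C=C/C(=O)OC/C=C/c1cc(OC)c(OC)cc1OC`: 100%
compound 2, `COc1cc(OC)c(OC)cc1/C=C/COC(=O)/C=C/c1ccccc1Cl`: 50%
compound 3, `COc1ccc(/C=C/C(=O)OC/C=C/c2cc(OC)c(OC)cc2OC)cc1`: 100%

Compound 1 and compound 3 share one core and differ only in the arrangement of the same atoms, (4-methoxyphenyl in place of 2-methoxyphenyl on a double-bonded chain carbon bound to a double-bonded chain carbon); in this assay this gives no change at the digits printed from compound 1 to compound 3 (within the scatter). Compound 2 is reached from compound 1 by chloro in place of methoxy on an aromatic carbon, and that step is a number 50 percentage points lower from compound 1 to compound 2 (beyond the scatter). Read from compound 2 to compound 3, the difference is a number 50 percentage points higher from compound 2 to compound 3 (beyond the scatter), so compound 3 stands level with compound 1 and furthest from compound 2.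

Compound 4, `COc1cc(OC)c(OC)cc1/C=C/COC(=O)/C=C/c1ccc(Cl)cc1`, has not yet been measured in this assay. It is derived from compound 3 by chloro in place of methoxy on an aromatic carbon. For the measured compounds named here, this is the same kind of change as the one from compound 1 to compound 2, but not the same change: there the chloro entered ortho to a large group, here it enters para to a large group. Because the earlier step was a number 50 percentage points lower from compound 1 to compound 2 (beyond the scatter), compound 4 is expected to fall from compound 3 by about a number 40 percentage points lower from compound 3 to compound 4 (beyond the scatter). The estimated value for compound 4 is therefore 60%, within a range from 30% to 100%.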

Compound 4, a percentage reported as activity, at one dose (the size of the read-out at that dose, not a potency): 50%
The estimate for compound 4 lay 10 percentage points above the measured number, and the stated range covers the measured number.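

In this assay, chloro in place of methoxy gives a number 50 percentage points lower from compound 3 to compound 4 (beyond the scatter), while the 4-chlorophenyl in place of 2-chlorophenyl gives no change at the digits printed from compound 2 to compound 4 (within the scatter), and the 4-chlorophenyl in place of 2-methoxyphenyl gives a number 50 percentage points lower from compound 1 to compound 4 (beyond the scatter). Set beside the earlier step, the exchange of methoxy for chloro carries over between the two cores without a difference beyond the scatter: the same change on two cores in this assay, a number 50 percentage points lower (beyond the scatter) from compound 1 to compound 2 and a number 50 percentage points lower (beyond the scatter) from compound 3 to compound 4, 0 percentage points apart, within the scatter of two such steps This shows that the change transferred between these two closely related cores at this single dose, but two cores that differ only in where the aromatic substituent sits are a narrow test, and the result neither explains the effect nor shows that it would carry to a more different core.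

The compounds shown leave open whether a group other than chloro, such as an amine, a carboxylic acid or a nitrile, would give a similar step in the same place. They also leave open whether the step would survive a longer chain on the shared core.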